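The source may report more compounds than this note shows. Statements on the series, on what has been measured and on what is new or still open speak of the compounds shown alone.

Compound 1 `Nc1ncc(-c2cccc(Cl)c2)c(-c2ccccc2)n1` reaches the limit > 80% in an assay on CHO cells for displacement of a labelled ligand from adenosine receptor A1 (Homo sapiens), read by scintillation counting, with a stated time of 1 h, tested at 1 uM; on this read-out lower numbers stand for less inhibition and higher numbers for more inhibition at the one concentration tested (going by the name of the read-out).
Compound 2 `O=C(Nc1ncc(-c2cccc(Cl)c2)c(-c2ccccc2)n1)C1CCCC1` gives 47% in this assay.
Compound 3 `OCCCNc1ncc(-c2cccc(Cl)c2)c(-c2ccccc2)n1` reaches the limit > 80% in this assay.

Compound 3 therefore stands at the top of the numbers shown, at the limit of > 80% in this assay, at which 2 of the 3 values shown sit, and not at a number of its own. Among the measured compounds shown here, the only unmeasured compound, compound 4 `Clc1cccc(-c2cnc(NCCCc3ccccc3)nc2-c2ccccc2)c1`, differs from it by phenyl in place of hydroxy on a saturated chain carbon, three bonds along the chain from a nitrogen on an aromatic ring. The measured steps all concern what sits on the nitrogen on the aromatic ring, not what sits further out on the chain: from hydrogen to cyclopentylcarbonyl the reading fell, a number at least 33 percentage points lower from compound 1 to compound 2 (beyond the scatter), from cyclopentylcarbonyl to 3-hydroxypropyl it rose again, a number at least 33 percentage points higher from compound 2 to compound 3 (beyond the scatter), while the step to 3-hydroxypropyl itself, a step that the two limits leave unreadable from compound 1 to compound 3, cannot be read against the limit. For the measured compounds named here, none of them exchanges hydroxy for phenyl, so no step bears directly on the change to compound 4. Since compound 3 sits at a limit, even a moderate loss would remain hidden and a gain could not be seen at all. Compound 4 is expected to stay near the top, with a step of a number at least 2 percentage points lower from compound 3 to compound 4 (that floor lies within the scatter) in this assay that is not expected to be readable beyond the scatter. The estimated value of compound 4 is 78%, between 55% and 92%.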

Compound 4, a percentage reported as inhibition, at one concentration (the size of the read-out at that concentration, not a potency): 33%
The estimate for compound 4 lay 45 percentage points above the measured number, and the stated range ends above it.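

Among the compounds shown here, at the place three bonds along the chain from a nitrogen on an aromatic ring, the group at the chain end proves to matter in this assay: phenyl in place of hydroxy gives a number at least 47 percentage points lower from compound 3 to compound 4 (beyond the scatter), the first reading of any change this far out. A chain on that nitrogen therefore does not by itself keep the reading high, as 3-phenylpropyl in place of hydrogen gives a number at least 47 percentage points lower from compound 1 to compound 4 (beyond the scatter), and 3-phenylpropyl in place of cyclopentylcarbonyl gives a number 14 percentage points lower from compound 2 to compound 4 (beyond the scatter), which leaves compound 4 lowest of the four. Compound 1 and compound 3 each sit at a limit, so the two large steps are floors and their full size cannot be read: the limit of > 80% in this assay, at which 2 of the 4 values shown sit.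

The compounds shown do not separate what the hydroxy contributes from what the phenyl takes away, and a plain propyl group on the same nitrogen would bear on that question. As far as these compounds go, it also remains open how an amine or a carboxylic acid at the chain end would read, or how a shorter phenethyl or benzyl group or a longer chain ending in phenyl would compare.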